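Ethyl to benzyl on the carbonyl-bound oxygen, in intestinal fluid

A few compounds are considered here, and "the series" means these few. Any claim that something is new, unique, unknown or untested is made for them only; others in the source may bear on it.

Compound 1 `CCOc1cc(NC(=O)C2(NC(=O)c3ccc4c(C5CCCC5)c(-c5ncc(Cl)cn5)n(C)c4c3)CCC2)ccc1/C=C/C(=O)N[C@@H](CCC(=O)O)C(N)=O` carries the (1-carbamoyl-3-carboxypropyl)amino group on the carbonyl carbon, and in an ADME assay for pharmacokinetics, in simulated intestinal fluid (a higher number here means that the compound lasts longer, a lower number that the compound disappears faster), compound 1 gives 4.23 h. Compound 2 `CCOC(=O)/C=C/c1ccc(NC(=O)C2(NC(=O)c3ccc4c(C5CCCC5)c(-c5ncc(Cl)cn5)n(C)c4c3)CCC2)cc1OCC` has ethoxy there instead; in this assay compound 2 reaches only the limit of > 5 h. Compound 3 `CCOc1cc(NC(=O)C2(NC(=O)c3ccc4c(C5CCCC5)c(-c5ncc(Cl)cn5)n(C)c4c3)CCC2)ccc1/C=C/C(=O)OCC(Cl)(Cl)Cl`, with 2,2,2-trichloroethoxy, also reaches only the limit of > 5 h. Two values thus sit at the limit of > 5 h in this assay, at which 2 of the 3 values shown sit. The steps of an at least 1.1-fold higher number from compound 1 to compound 2 (0.07 log units; that floor lies within the scatter) and an at least 1.1-fold higher number from compound 1 to compound 3 (0.07 log units; that floor lies within the scatter) are floors, and a step that the two limits leave unreadable from compound 2 to compound 3 remains unreadable. Compound 4 `CCOc1cc(NC(=O)C2(NC(=O)c3ccc4c(C5CCCC5)c(-c5ncc(Cl)cn5)n(C)c4c3)CCC2)ccc1/C=C/C(=O)OCc1ccccc1` differs from compound 2 by phenyl in place of methyl on a saturated chain carbon bound to an oxygen next to a carbonyl group. Since the nearest change at this position gave a step that the two limits leave unreadable from compound 2 to compound 3, compound 4 is expected to show a step that the limit leaves unreadable from compound 2 to compound 4, with no movement beyond the scatter. Compound 4 is estimated at 5.5 h, between 2.5 h and 12 h.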

Compound 4, half-life: > 5 h
Compound 4 was reported as a limit; the forecaster's own chance of this, stated with the estimate: 55%; the middle value lies beyond the limit too.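

In this assay compound 4 gives > 5 h, a limit and not a number, so benzyloxy on the carbonyl carbon ends where ethoxy and 2,2,2-trichloroethoxy already stand. Among the compounds shown here, the only readable step is an at least 1.1-fold higher number from compound 1 to compound 4 (0.07 log units; that floor lies within the scatter), while the steps among compound 2, compound 3 and compound 4 cannot be read. The limit now holds most of the set: the limit of > 5 h in this assay, at which 3 of the 4 values shown sit.

On these data alone, how long compound 2, compound 3 and compound 4 actually last in this assay stays open. Also open, as far as these compounds go, is whether an amine or a longer chain on the saturated chain carbon bound to an oxygen next to a carbonyl group would give a value under the limit.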